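Methyl-to-hydrogen step repeated on a second core

The compounds below may be only part of what the source reports. "The series", "measured", "known", "first", "only" and "open" are said of these compounds alone.

Compound 1 `CCC(C)C(C(=O)Nc1ccc(C(C)=O)cc1)N(C(=O)c1ccccc1)S(=O)(=O)c1ccc(C)cc1` was run in a functional assay for inhibition, read by spectrophotometry, with a stated time of 20 min, tested at 1 mg/mL (on this read-out higher numbers stand for a stronger effect at the one concentration tested and lower numbers for a weaker effect), and gave 18.6%. Compound 2 `CC(=O)c1ccc(NC(=O)C(C(C)C)N(C(=O)c2ccccc2)S(=O)(=O)c2ccc(C)cc2)cc1` differs from compound 1 by hydrogen in place of methyl on a saturated chain carbon, three bonds along the chain from an amide-type nitrogen and a carbonyl carbon; in this assay compound 2 gives 15.6%, and the step of a number 3 percentage points lower from compound 1 to compound 2 (within the scatter). Compound 3 `CCC(C)C(C(=O)Nc1ccc(C(C)=O)cc1)N(C(=O)c1ccccc1)S(=O)(=O)c1ccccc1` carries the other core, which differs from the core of compound 1 by hydrogen in place of methyl on an aromatic carbon; in this assay compound 3 gives 9.71%, the step being a number 8.9 percentage points lower from compound 1 to compound 3 (within the scatter). Compound 4 `CC(=O)c1ccc(NC(=O)C(C(C)C)N(C(=O)c2ccccc2)S(=O)(=O)c2ccccc2)cc1` is not yet measured and differs from compound 3 by hydrogen in place of methyl on a saturated chain carbon, three bonds along the chain from an amide-type nitrogen and a carbonyl carbon. This is the same change as that from compound 1 to compound 2, made on the other core, with the place of the change the same in both cases. The earlier instance is the only one available and it stayed within the usual scatter. Compound 4 is therefore expected to show a step of a number 2.7 percentage points lower from compound 3 to compound 4 (within the scatter), resting on the earlier step of a number 3 percentage points lower from compound 1 to compound 2 (within the scatter). That would keep compound 4 close to compound 3. Compound 4 is estimated at 7% in this assay, with an expected range from 0% to 17%.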

Compound 4, a percentage reported as inhibition, at one concentration (the size of the read-out at that concentration, not a potency): 32.1%
The estimate for compound 4 lay 25.1 percentage points below the measured number; measured number above the stated range.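

In this assay, the change from sec-butyl to isopropyl did not carry from one core to the other, with a number 22.4 percentage points higher from compound 3 to compound 4 (beyond the scatter): the same change on two cores in this assay, a number 3 percentage points lower (within the scatter) from compound 1 to compound 2 and a number 22.4 percentage points higher (beyond the scatter) from compound 3 to compound 4, 25.4 percentage points apart, beyond the scatter of two such steps
The replacement of methyl by hydrogen on an aromatic carbon behaves the same way, with a number 16.5 percentage points higher from compound 2 to compound 4 (beyond the scatter): the same change on two cores in this assay, a number 8.9 percentage points lower (within the scatter) from compound 1 to compound 3 and a number 16.5 percentage points higher (beyond the scatter) from compound 2 to compound 4, 25.4 percentage points apart, beyond the scatter of two such steps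
These two comparisons rest on the same four compounds and show that, within this set, the outcome of each change depends on the group present at the other place; they do not give a reason for this or establish a rule for the wider series, and each number speaks only of a stronger or weaker effect at the one concentration tested.

On these data alone, it remains open whether this dependence also appears with a longer chain or a cyclohexyl group in place of sec-butyl, or with methoxy or chlorine in place of the methyl on the aromatic carbon. As far as these compounds go, the shape of the response of compound 4 across other concentrations also remains open.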